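Working notes: three measured compounds and one awaiting measurement

The source may hold more compounds than are shown below. What is called first, only, known or untested is meant among the compounds shown, and "the series" means these compounds.

Measured so far in a functional assay on A-375 cells (Homo sapiens) for inhibition; a higher number here means a weaker inhibitor, a lower number a stronger inhibitor:
Compound 1 `N#CC1CN1C(=O)Nc1ccc(Cl)c(Cl)c1`: 5900 nM
Compound 2 `CCCCNC(=O)N1CC1C#N`: 15000 nM
Compound 3 `N#CC1CN1C(=O)Nc1cccnc1`: 12000 nM

Compound 2 gives the highest of the three numbers in this assay. Its nearest neighbour is compound 3, whose value sits within the usual scatter of the value of compound 2, so no order between those two can be stated. Compound 1 sits further away, beyond the scatter, with the lower number of the pair. Among the measured compounds shown here, no two of the measured compounds differ in one place only, so no single structural step has yet been quantified.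

Compound 4 `CC(C)(C)NC(=O)N1CC1C#N` has not yet been measured. It differs from compound 2 as follows: tert-butyl in place of butyl on an amide-type nitrogen. The two compounds have the same atoms, joined differently.

For the measured compounds named here, nothing measured so far speaks to a change of this kind on that nitrogen, and the three measured values give no anchor for it. The expectation is therefore that the step from compound 2 to compound 4 in this assay lies within the scatter, in no particular direction: no change at the digits printed from compound 2 to compound 4 (within the scatter) is the estimated step. The estimated value for compound 4 in this assay is 15000 nM, expected to fall between 6000 nM and 38000 nM.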

Compound 4, half-maximal inhibitory concentration: 418000 nM
Compound 4: the middle estimate sits 28-fold (1.45 log units) below what was measured, and the stated range ends below it.
By their numbers in this assay, from the lowest: compound 1; then compounds 3 and 2 (each within the scatter of the next); then compound 4.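

In this assay, the step from butyl to tert-butyl on an amide-type nitrogen gives a 28-fold higher number from compound 2 to compound 4 (1.45 log units; beyond the scatter), the first single-place step quantified in this series and a large one. The leaving and entering groups hold the same count of carbon atoms, and neither carries a ring, a charge or any hydrogen-bond donor or acceptor, so this position distinguishes between two arrangements of the same atoms and does not respond to atom count alone. No measurement shown here accounts for the size of this step.

Going by these compounds, whether the weaker inhibition of compound 4 is specific to tert-butyl or begins with a smaller branched group such as isopropyl remains open, as does the outcome for a cyclobutyl ring on the same nitrogen. A longer chain than butyl, or a butyl chain ending in an amine or a carboxylic acid, would show whether compound 2 sits near the best of the straight chains or merely at one point along a wider range.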